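The source may hold more compounds than are shown below. What is called first, only, known or untested is meant among the compounds shown, and "the series" means these compounds.

Measured compounds:
- Compound 1 `C/C(=N\CC(C)C)c1c(O)c2ccccc2oc1=O`: in an assay on isolated protein for inhibition of myosin-2 (Bos taurus), read by spectrophotometry, with a stated time of 24 min (a higher number here means a weaker inhibitor, a lower number a stronger inhibitor), compound 1 gives 34000 nM.
- Compound 2 `C/C(=N\CCO)c1c(O)c2ccccc2[nH]c1=O`: compound 2 reaches only the limit >= 100000 nM, which is a limit of the assay and not a number.
- Compound 3 `C/C(=N\CC(C)C)c1c(O)c2ccccc2[nH]c1=O`: compound 3 likewise reaches only the limit >= 100000 nM, again a limit and not a number.

Going by the values given here, compound 1 thus stands as the only compound among the three with a real number; the other two sit at the limit of >= 100000 nM in this assay, at which 2 of the 3 values shown sit. Among the compounds with values here, the one step between measured compounds that differ in a single place, a step that the two limits leave unreadable from compound 2 to compound 3, swaps a group on the saturated chain carbon bound to the double-bonded nitrogen, but both ends of that step are limits, so its size cannot be read.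

Compound 4 `CCC(C)/N=C(\C)c1c(O)c2ccccc2oc1=O`, not yet measured, differs from compound 1 by sec-butyl in place of isobutyl on a double-bonded nitrogen. Within the data shown here, this change touches the same nitrogen substituent region as the unreadable step, but no measured step gives a readable size for altering the branching of that chain. With nothing to point either way, the expectation is no step beyond the usual scatter, that is, compound 4 is expected to show about no change at the digits printed from compound 1 to compound 4 (within the scatter).

Compound 4 is therefore estimated at 34000 nM in this assay, with an expected range from 12000 nM to 100000 nM.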

Compound 4, half-maximal inhibitory concentration: >= 100000 nM
Compound 4 was reported as a limit; the forecaster's own chance of this, stated with the estimate: 25%; at least 2.9-fold (0.46 log units) between middle value and limit.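

Sec-butyl in place of isobutyl on a double-bonded nitrogen gives, in this assay, an at least 2.9-fold higher number from compound 1 to compound 4 (0.46 log units; beyond the scatter), which is beyond the usual scatter and means a weaker inhibitor. Going by these compounds alone, this is the first readable step at this nitrogen, as the earlier step there cannot be read, and it shows that the four-carbon chain cannot simply be rejoined without a measurable loss, even though the leaving and entering groups have the same counts of heavy atoms, with no ring and no charge. Compound 4 is reported only as a limit, not a number, and it joins the compounds held there: the limit of >= 100000 nM in this assay, at which 3 of the 4 values shown sit.

This single pair shows that the way the chain is joined matters for compound 1, but it gives no reason for the loss and no trend across other chains. The compounds shown leave open whether a different group on this nitrogen, such as a straight butyl chain, a longer chain, a cyclohexyl ring, an amine or a carboxylic acid, would match or better compound 1 at 34000 nM.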